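The compounds below may be only part of what the source reports. "The series", "measured", "known", "first", "only" and "open" are said of these compounds alone.

Values in an ADME assay on a cell-free system (plasma, Homo sapiens) for protein binding:
- compound 1 `COCc1nc2nc(C)cc(Nc3ccc(C(F)(F)F)cc3)n2n1` gives 75.6%
- compound 2 `COCCc1nc2nc(C)cc(Nc3ccc(S(F)(F)(F)(F)F)cc3)n2n1` gives 87.7%
- compound 3 `COCc1nc2nc(C)cc(Nc3ccc(S(F)(F)(F)(F)F)cc3)n2n1` gives 91.7%

Compound 3 cannot be told apart from compound 2 within the scatter, and it stands clear of compound 1, with a 2.9-fold lower unbound fraction from compound 1 to compound 3 (0.47 log units; beyond the scatter).

Compound 4 `CCC(F)(F)c1nc2nc(C)cc(Nc3ccc(S(F)(F)(F)(F)F)cc3)n2n1` has 1,1-difluoropropyl in place of methoxymethyl on an aromatic carbon. Within the data shown here, no measured step makes this exact swap. The closest change, in the same chain, is a 1.5-fold lower unbound fraction from compound 2 to compound 3 (0.17 log units; within the scatter), which offers little guidance. The other step, a 2.9-fold lower unbound fraction from compound 1 to compound 3 (0.47 log units; beyond the scatter), lies elsewhere on the molecule, but there too a larger fluorine-bearing group entered, so a step of similar size toward more binding is expected. The expected step is a 2.4-fold lower unbound fraction from compound 3 to compound 4 (0.38 log units; beyond the scatter). Compound 4 is estimated at 96.5%, with an expected range of 93% to 98.8%.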

Compound 4, plasma protein binding: 97.7%
The estimate for compound 4 lay 1.5-fold (0.18 log units) (unbound fraction) above the measured number; the range from low to high includes it.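

At this position on the five-membered aromatic ring, the side chain can clearly change this assay: 1,1-difluoropropyl in place of methoxymethyl gives a step beyond the scatter (a 3.6-fold lower unbound fraction from compound 3 to compound 4 (0.56 log units; beyond the scatter)), whereas the earlier chain change here stayed within it. Against 2-methoxyethyl, the same group gives a larger step (a 5.3-fold lower unbound fraction from compound 2 to compound 4 (0.73 log units; beyond the scatter)). No evidence here explains these steps.

Open, on these data alone, is how much of the step belongs to the two fluorine atoms and how much to the chain itself. A plain propyl chain or an amine at this position could give a different result.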